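Aryl hydrazone variation on the shared core

The source may report more compounds than this note shows. Statements on the series, on what has been measured and on what is new or still open speak of the compounds shown alone.

In a functional assay on MGC-803 cells (Homo sapiens) for antiproliferative activity, read by MTT assay, with a stated time of 72 h (a higher number here means a weaker inhibitor, a lower number a stronger inhibitor), compound 2 `CCCSc1nc(N/N=C/c2ccc(Cl)cc2)c2nnn(Cc3ccccc3)c2n1` gives only a limit, > 64000 nM. This is the limit (the limit of > 64000 nM in this assay, at which 1 of the 3 values shown sits), so compound 2 stands at the weak end of the numbers shown, without a number of its own. Compound 3 `CCCSc1nc(N/N=C(\C)c2ccc(O)cc2)c2nnn(Cc3ccccc3)c2n1` gives 16700 nM, and compound 1 `CCCSc1nc(N/N=C(\C)c2ccccc2O)c2nnn(Cc3ccco3)c2n1` gives 4760 nM. Among the compounds with values here, the one measured step at the position in question is an at least 3.8-fold lower number from compound 2 to compound 3 (0.58 log units; beyond the scatter); it swaps in a different group than the one now proposed, so it bears on compound 4 only as a precedent for change at that place. Compound 4 `CCCSc1nc(N/N=C/c2ccc3ccccc3c2)c2nnn(Cc3ccccc3)c2n1` differs from compound 2 by naphthalen-2-yl in place of 4-chlorophenyl on a carbon with a double bond to nitrogen. With compound 2 known only as a limit, a step of an at least 1.6-fold lower number from compound 2 to compound 4 (0.20 log units; that floor lies within the scatter) is expected, with a real chance of another limit. Compound 4 is therefore estimated at 40000 nM, between 8000 nM and 128000 nM.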

Compound 4, half-maximal inhibitory concentration: > 64000 nM
Compound 4: only a limit was reported (the forecaster's own chance of this, stated with the estimate: 45%); middle value at least 1.6-fold (0.20 log units) from the limit.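

Compound 2 and compound 4 both stand only as limits, so no step between them can be read: the limit of > 64000 nM in this assay, at which 2 of the 4 values shown sit.

Going by these compounds, whether naphthalen-2-yl in place of 4-chlorophenyl changes the number at all remains open.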